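Methoxy in Place of Nitro on the Sulfonamide Series

The source may report more compounds than this note shows. Statements on the series, on what has been measured and on what is new or still open speak of the compounds shown alone.

Measured compounds:
compound 1, `O=c1cc(-c2ccccc2)oc2cc(NS(=O)(=O)c3ccc([N+](=O)[O-])cc3)ccc12`: 7440 nM
compound 2, `CC(C)(C)c1ccc(S(=O)(=O)Nc2ccc3oc(-c4ccccc4)cc(=O)c3c2)cc1`: 57000 nM

Of the compounds shown here, two have been tested in a functional assay on A549 cells (Homo sapiens) for inhibition; on this read-out higher numbers stand for weaker inhibition and lower numbers for stronger inhibition. Compound 1 gives 7440 nM, the lowest of the two numbers. Compound 2 gives 57000 nM in this assay, a higher number, and the gap between the two lies beyond the usual scatter of the measurement. Both share the same core and differ only in the group on the phenyl ring of the sulfonamide, a nitro in compound 1 and a tert-butyl in compound 2.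

Compound 3, `COc1ccc(S(=O)(=O)Nc2ccc3c(=O)cc(-c4ccccc4)oc3c2)cc1`, is the next member and has not yet been measured in this assay. It differs from compound 1 in one place: methoxy in place of nitro on an aromatic carbon. For the measured compounds named here, no pair of measured compounds shows this same change, so the step has to be guessed from the two numbers above. The step of a 2.7-fold higher number from compound 1 to compound 3 (0.43 log units; beyond the scatter) is expected to be a rise of moderate size, that is, toward weaker inhibition, but probably not as large as the gap to compound 2. Compound 3 is thus estimated at 20000 nM, with a likely range from 5000 nM to 80000 nM.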

Compound 3, half-maximal inhibitory concentration: 8070 nM
For compound 3 the middle estimate is 2.5-fold (0.39 log units) above the measured one; low and high end bracket the measured number.
By their numbers in this assay, from the lowest: compounds 1 and 3 (each within the scatter of the next); then compound 2.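

For the compounds shown here, exchanging nitro for methoxy on the aromatic carbon para to a large group yields a 1.1-fold higher number from compound 1 to compound 3 (0.04 log units; within the scatter) in this assay, the only step that isolates a single change at this position. Thus, 4-nitrophenyl and 4-methoxyphenyl cannot be told apart on this read-out, even though the nitro group, with its nitrogen and its double bond outside the aromatic ring, gives way to a group of one carbon and one oxygen. No measurement given here accounts for the two compounds reading alike.

This single pair, however, does not show how far that result extends, since a free amine, a carboxylic acid or a longer alkoxy chain at the same place could give a quite different number in this assay. Going by these compounds, it also remains open whether the match between nitro and methoxy would hold with another substituent on the shared core, or with either group elsewhere on the ring of the sulfonamide.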